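A few compounds are considered here, and "the series" means these few. Any claim that something is new, unique, unknown or untested is made for them only; others in the source may bear on it.

Measured so far:
- compound 1, `NC(=O)c1cccc(-c2cnc(C(O)CCc3ccc(-c4ccccc4)cc3)o2)n1`: 20000 nM
- compound 2, `O=C(O)c1cccc(-c2cnc(C(=O)CCc3ccc(-c4ccc(CN5CCCCC5)cc4)cc3)o2)n1`: 44 nM
- compound 3, `COC(=O)c1ccc(-c2cnc(C(=O)CCc3ccc(-c4ccccc4)cc3)o2)cn1`: 0.6 nM

Compound 1 holds the highest number of the three in an assay for inhibition of Fatty-acid amide hydrolase 1 (Rattus norvegicus); on this read-out lower numbers stand for stronger inhibition and higher numbers for weaker inhibition. The nearest value is that of compound 2, which sits well beyond the scatter below it, and compound 3 lies further still, far beyond the scatter. Going by the values given here, neither compound 2 nor compound 3 differs from compound 1 in a single place, so no step between measured compounds is available to read from.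

The unmeasured compound 4, `COC(=O)c1ccc(-c2cnc(C(O)CCc3ccc(-c4ccccc4)cc3)o2)nc1`, arises from compound 1 by one change on the shared core:

5-(methoxycarbonyl)pyridin-2-yl in place of 6-carbamoylpyridin-2-yl on an aromatic carbon

Compound 3 also carries the 5-(methoxycarbonyl)pyridin-2-yl group and gives 0.6 nM in this assay, but compound 3 differs from compound 1 in more than one place, so its value cannot be assigned to this exchange alone. The rest of compound 4 matches compound 1, which is the weakest of the three measured compounds. The expected step from compound 1 to compound 4 is therefore a modest decrease in number, estimated as a 2.5-fold lower number from compound 1 to compound 4 (0.40 log units; beyond the scatter), with a real chance that it lies within the scatter. For compound 4 the estimate in this assay is 8000 nM, with a range from 2000 nM to 30000 nM.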

Compound 4, inhibition constant: 1100 nM
Compound 4: middle estimate off by 7.3-fold (0.86 log units), on the high side; measured number outside the range, below it.
By their numbers in this assay, from the lowest: compound 3; then compound 2; then compound 4; then compound 1.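

In this assay, going by these compounds alone, the exchange of 6-carbamoylpyridin-2-yl for 5-(methoxycarbonyl)pyridin-2-yl on the aromatic carbon next to the ring oxygen gives an 18-fold lower number from compound 1 to compound 4 (1.26 log units; beyond the scatter) with the rest of the molecule unchanged, the first single-place reading. This position is therefore sensitive to the group it carries, and compound 1 owes its high number at least partly to the 6-carbamoylpyridin-2-yl group rather than solely to the rest of its structure, which compound 4 keeps. No measurement shown here accounts for the size of this step.

The exchange alters the carbonyl group and its location on the pyridine ring together, so the compounds shown do not separate the contribution of the ester from that of its placement; 5-carbamoylpyridin-2-yl would isolate the first and 6-(methoxycarbonyl)pyridin-2-yl the second. Also open, as far as these compounds go, is whether another group on the pyridine ring, such as the nitrile in 5-cyanopyridin-2-yl, would follow compound 4, and whether the same exchange gives a step of similar size in compounds with a different remainder.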